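Extending the propanoyl chain of a pyrazoline coumarin

A few compounds are considered here, and "the series" means these few. Any claim that something is new, unique, unknown or untested is made for them only; others in the source may bear on it.

In a functional assay on MGC-803 cells (Homo sapiens) for cytotoxicity, read by MTT assay, with a stated time of 48 h (on this read-out higher numbers stand for weaker inhibition and lower numbers for stronger inhibition), compound 1 `CC1=NN(C(=O)c2ccc(C)cc2)C(c2cc(Br)cc(Br)c2O)C1` gives 56500 nM, while compound 2 `CCC(=O)N1N=C(c2cc3ccccc3oc2=O)CC1c1ccccc1` gives 5300 nM, the lower of the two numbers; the gap to compound 1 lies beyond the scatter. Compound 3 `CC1CCCCN1CC(=O)N1N=C(c2cc3ccccc3oc2=O)CC1c1ccccc1` departs from compound 2 by a single change: 2-methylpiperidin-1-yl in place of methyl on a saturated chain carbon bound to a carbonyl carbon. Among the compounds with values here, no measured pair shows this kind of change, so its effect in this assay is unknown. Compound 3 is expected to stay near compound 2, with a step of a 1.5-fold lower number from compound 2 to compound 3 (0.18 log units; within the scatter) that may not exceed the scatter. Compound 3 is estimated at 3500 nM, within 900 nM to 14000 nM.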

Compound 3, half-maximal inhibitory concentration: "not active" (no number reported)
For compound 3 the study gives words and no number, and the estimate cannot be compared.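

Within the data shown here, compound 3 is reported only in words, as not active, with no number, so no step from compound 2 to compound 3 can be read. The compounds shown leave open how large a change the 2-methylpiperidin-1-yl group brings. No evidence at hand bears on this result.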